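This account rests on a few compounds, and the source may have more. Where it says the series, first, only, none or still open, it means among the compounds named here.

Of the compounds shown here, two sharing a core have so far been measured in a functional assay on THP-1 cells (Homo sapiens) for inhibition, read by ELISA, with stated times of 2 h and 48 h; on this read-out lower numbers stand for stronger inhibition and higher numbers for weaker inhibition. In this assay compound 1 (`[O-]/[N+](=C\c1cn(-c2ccccc2)nn1)c1ccccc1`) gives 8800 nM, and compound 2 (`[O-]/[N+](=C\c1cn(CCC(F)(F)C(F)(F)C(F)(F)C(F)(F)C(F)(F)C(F)(F)C(F)(F)C(F)(F)F)nn1)c1ccccc1`) gives 11700 nM. For the measured compounds named here, compound 2 therefore stands within the usual scatter of compound 1, its only neighbour on the numbers available, and neither can be ranked above the other.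

The next compound, compound 3 (`[O-]/[N+](=C\c1cn(CCC(F)(F)C(F)(F)C(F)(F)C(F)(F)C(F)(F)C(F)(F)C(F)(F)C(F)(F)F)nn1)Cc1ccccc1`), keeps the long fluorinated chain of compound 2 and carries benzyl in place of phenyl on a double-bonded nitrogen.

Going by the values given here, no measured pair shows what a change of this kind does, so the expectation is weakly grounded. The expected outcome in this assay is no shift beyond the scatter, in either direction, and the starting point is compound 2 at 11700 nM. The estimate is a 1.2-fold lower number from compound 2 to compound 3 (0.07 log units; within the scatter), an expected step too small to be told from repeat measurements. For compound 3 the estimated value is 10000 nM, with an expected range of 4000 nM to 25000 nM.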

Compound 3, half-maximal inhibitory concentration: 17000 nM
Compound 3: the middle estimate sits 1.7-fold (0.23 log units) below what was measured; low and high end bracket the measured number.
By their numbers in this assay, from the lowest: compounds 1, 2 and 3 (each within the scatter of the next).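

In this assay, for the compounds shown here, the swap of benzyl in place of phenyl on a double-bonded nitrogen gives the first step that can be read between compounds differing in one place: a 1.5-fold higher number from compound 2 to compound 3 (0.16 log units; within the scatter). With the long fluorinated chain held constant, the read-out therefore does not separate benzyl from phenyl at this position, and the extra carbon of benzyl has no effect that can be told from repeat measurements. No measurement is available that bears on this result.

From the compounds shown here alone, what remains open is whether a group of another kind on this nitrogen, such as a phenethyl group, a cyclohexyl group, or a benzyl carrying a carboxylic acid or an amine on its ring, would give a step beyond the scatter in this assay. Also open, going by these compounds, is whether benzyl and phenyl would still read alike if the group on the other side of the shared core were something other than the long fluorinated chain, since this single pair tests the change against that chain alone.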